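The source may report more compounds than this note shows. Statements on the series, on what has been measured and on what is new or still open speak of the compounds shown alone.

Working notes on the cytotoxicity series.

Three compounds carry the shared core: compound 1 `Cc1cc(N2CC[C@@H](C)[C@@H](N(C)c3ncnc4[nH]ccc34)C2)n2ncnc2n1`, compound 2 `CCCSc1nc2nc(C)cc(N3CC[C@@H](C)[C@@H](N(C)c4ncnc5[nH]ccc45)C3)n2n1` and compound 3 `CCc1cc(N2CC[C@@H](C)[C@@H](N(C)c3ncnc4[nH]ccc34)C2)n2ncnc2n1`. In a toxicity assay on GES1 cells (Homo sapiens) for inhibition, read by MTT assay, with a stated time of 72 h (a higher number here means a weaker inhibitor, a lower number a stronger inhibitor), compound 1 gives 57900 nM. In this assay compound 2 gives 67100 nM, the highest of the two numbers in hand, with compound 1 as its nearest neighbour. For the measured compounds named here, compound 3 reports only > 100000 nM, which is a limit of this assay and not a number; it is the one value here at the limit of > 100000 nM in this assay, at which 1 of the 3 values shown sits.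

Both measured steps stay inside the scatter: a 1.2-fold higher number from compound 1 to compound 2 (0.06 log units; within the scatter), where propylsulfanyl replaces hydrogen on an aromatic carbon, and an at least 1.7-fold higher number from compound 1 to compound 3 (0.23 log units; that floor lies within the scatter), where methyl replaces hydrogen on a saturated chain carbon bound to an aromatic carbon.

Compound 4 `Cc1cc(N2CC[C@@H](C)[C@@H](N(C)c3ncnc4[nH]ccc34)C2)n2nc(SCC3CC3)nc2n1` is not yet measured. It differs from compound 2 by cyclopropyl in place of ethyl on a saturated chain carbon bound to a sulfur. Going by the values given here, the step that bears on it is the one from compound 1 to compound 2, since that step installs the propylsulfanyl group that is now rebuilt, and it changed nothing beyond the scatter. No step beyond the scatter is therefore expected in this assay in either direction. Compound 4 is expected to give 70000 nM, with a range from 35000 nM to 140000 nM, and compound 4 is expected to stand at a 1.0-fold higher number from compound 2 to compound 4 (0.02 log units; within the scatter) relative to compound 2.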

Compound 4, half-maximal inhibitory concentration: 27900 nM
Beside the measured number, compound 4's estimate is 2.5-fold (0.40 log units) above it; the measured number lies below the stated range.
By their numbers in this assay, from the lowest: compound 4; then compounds 1 and 2 (each within the scatter of the next). At a limit, above all of these: compound 3.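

At the chain on sulfur, the change from ethyl to cyclopropyl moves the reading in this assay: the swap gives a 2.4-fold lower number from compound 2 to compound 4 (0.38 log units; beyond the scatter), whereas installing propylsulfanyl on the aromatic carbon gave only a 1.2-fold higher number from compound 1 to compound 2 (0.06 log units; within the scatter). Set against hydrogen on that aromatic carbon, (cyclopropylmethyl)sulfanyl gives a 2.1-fold lower number from compound 1 to compound 4 (0.32 log units; beyond the scatter), so substitution at this position can shift the number, but with these compounds that is seen only for the cyclopropylmethyl chain and not for the propyl chain. Nothing shown for these compounds accounts for the step from ethyl to cyclopropyl.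

The compounds shown leave open whether the step belongs to the three-membered ring itself or to the extra carbon that enters with it, a question that a butyl or isobutyl chain on the sulfur would address. They also leave open how far the reading moves with a larger or charged end on that chain, such as a phenyl ring, an amine or a carboxylic acid, and whether the sulfur can be replaced by oxygen.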